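The source may report more compounds than this note shows. Statements on the series, on what has been measured and on what is new or still open speak of the compounds shown alone.

In a functional assay on MDA-MB-468 cells (Homo sapiens) for antiproliferative activity, read by sulforhodamine B assay, with a stated time of 48 h (on this read-out higher numbers stand for weaker inhibition and lower numbers for stronger inhibition), two compounds sharing one core have been measured so far. Compound 1 `COc1ccc(-c2nsc3c2NC(=O)CC3c2cccc(Cl)c2)cc1` gives 174 nM, while compound 2 `COc1ccc(-c2nsc3c2NC(=O)CC3c2cccc(F)c2)cc1` gives 1940 nM, the higher of the two numbers. Compound 3 `COc1ccc(-c2nsc3c2NC(=O)CC3c2ccc(F)cc2)cc1` has the same atoms as compound 2, joined differently: 4-fluorophenyl in place of 3-fluorophenyl on a saturated ring carbon, with 4-fluorophenyl in place of 3-fluorophenyl on a saturated ring carbon. Within the data shown here, only one measured step bears on this change, an 11-fold higher number from compound 1 to compound 2 (1.05 log units; beyond the scatter), a large step for fluoro in place of chloro on an aromatic carbon. Among the measured compounds shown here, that step shows how far one halogen exchange can shift the number, but no measured pair tests a relocated fluorine, so the direction remains open. The expected result is no shift beyond the scatter, though a wide range stays plausible. The estimated step is a 1.2-fold lower number from compound 2 to compound 3 (0.08 log units; within the scatter). Compound 3 is expected at 1600 nM, with an estimated range of 400 nM to 6000 nM.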

Compound 3, half-maximal inhibitory concentration: 2350 nM
Beside the measured number, compound 3's estimate is 1.5-fold (0.17 log units) below it; measured number inside the range.
By their numbers in this assay, from the lowest: compound 1; then compounds 2 and 3 (each within the scatter of the next).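

Moving the fluorine, with 4-fluorophenyl in place of 3-fluorophenyl on the saturated ring carbon, gives a 1.2-fold higher number from compound 2 to compound 3 (0.08 log units; within the scatter) in this assay, so these two fluorophenyl groups are not told apart here. The exchange of 3-chlorophenyl for 4-fluorophenyl gives a 14-fold higher number from compound 1 to compound 3 (1.13 log units; beyond the scatter), a large step of the same order as the earlier exchange of chloro for fluoro, so among these three compounds the change of halogen moves the number and the change of fluorine placement does not. Nothing at hand gives a reason for either result.

Whether a chloro group keeps its lower number as 4-chlorophenyl remains open, since the only chloro compound shown carries 3-chlorophenyl. Going by these compounds, it also remains open how a bromo, methyl, amine or carboxylic acid group on this phenyl ring would compare.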